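Adding chloro to the benzyl group of compound 3

The source may hold more compounds than are shown below. What is called first, only, known or untested is meant among the compounds shown, and "the series" means these compounds.

Compound 1 `COc1ccc(CN(C(=O)CSc2nc3ccccc3s2)c2cc(OC)c(OC)c(OC)c2)cc1N=[N+]=[N-]`: 187 nM
Compound 2 `COc1cc(CN(C(=O)CSc2nc3ccccc3s2)c2cc(OC)c(OC)c(OC)c2)cc(OC)c1OC`: 45700 nM
Compound 3 `COc1cc(N(Cc2ccccc2)C(=O)CSc2nc3ccccc3s2)cc(OC)c1OC`: 44300 nM

In a functional assay on MGC-803 cells (Homo sapiens) for antiproliferative activity, read by MTT assay, with a stated time of 48 h (a higher number here means a weaker inhibitor, a lower number a stronger inhibitor), compound 3 stands at 44300 nM, within the scatter of compound 2 and far above compound 1. Compound 4 `COc1cc(N(Cc2ccc(Cl)cc2)C(=O)CSc2nc3ccccc3s2)cc(OC)c1OC` differs from compound 3 by chloro in place of hydrogen on an aromatic carbon, turning benzyl into 4-chlorobenzyl. Two measured steps alter this same group. The first is a 1.0-fold lower number from compound 2 to compound 3 (0.01 log units; within the scatter). The second, a 240-fold higher number from compound 1 to compound 3 (2.37 log units; beyond the scatter), is large, but it involves the 3-azido-4-methoxyphenyl group of compound 1, and neither step involves chloro. The expected change is therefore a 1.3-fold lower number from compound 3 to compound 4 (0.13 log units; within the scatter), with no move beyond the scatter anticipated. Compound 4 is estimated at 33000 nM, with an expected range of 10000 nM to 75000 nM.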

Compound 4, half-maximal inhibitory concentration: > 80000 nM
Compound 4 gave a limit, no number; the forecaster's own chance of this, stated with the estimate: 20%; middle value at least 2.4-fold (0.38 log units) from the limit.
By their numbers in this assay, from the lowest: compound 1; then compounds 3 and 2 (each within the scatter of the next). At a limit, above all of these: compound 4.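

In this assay compound 4 gives only a limit of the assay, > 80000 nM, not a number. Chloro on this aromatic carbon, para to a large group, brings no measurable gain: the steps are an at least 1.8-fold higher number from compound 3 to compound 4 (0.25 log units; that floor lies within the scatter) and an at least 1.7-fold higher number from compound 2 to compound 4 (0.24 log units; that floor lies within the scatter), and both floors stay within the scatter, so neither fixes how far the value moves. Among the compounds shown here, the large step is an at least 420-fold higher number from compound 1 to compound 4 (2.63 log units; beyond the scatter), which leaves the 3-azido-4-methoxyphenyl group of compound 1 as the only change here tied to a low value. The compounds shown leave open whether fluoro or an amine in place of chloro would behave differently. They also leave open whether the azido group alone, without the methoxy group, would give a value like that of compound 1.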